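Moving a Methyl Group: One Change, Measured Once, Expected Again

The source may report more compounds than this note shows. Statements on the series, on what has been measured and on what is new or still open speak of the compounds shown alone.

Measured compounds:
Compound 1, `Cc1cccc(-n2cc(-c3ccccc3NS(=O)(=O)c3c[nH]c(=O)[nH]c3=O)nn2)c1`: 3150 nM
Compound 2, `Cc1ccc(-n2cc(-c3ccccc3NS(=O)(=O)c3c[nH]c(=O)[nH]c3=O)nn2)cc1`: 2190 nM
Compound 3, `Cc1cccc(-n2cc(-c3cccc(NS(=O)(=O)c4c[nH]c(=O)[nH]c4=O)c3)nn2)c1`: 4080 nM

All three were tested in a functional assay on OVCAR-3 cells (Homo sapiens) for antiproliferative activity, read by MTT assay, with a stated time of 24 h; a higher number here means a weaker inhibitor, a lower number a stronger inhibitor. In this assay compound 1 gives 3150 nM. Compound 2 differs from compound 1 by a single change, (4-methylphenyl in place of 3-methylphenyl on an aromatic nitrogen), and this brought a 1.4-fold lower number from compound 1 to compound 2 (0.16 log units; within the scatter), so the two compounds cannot be told apart by this measurement.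

Compound 3 carries a different core; how the core of compound 3 differs from that of compound 1 is not broken down here. In this assay compound 3 gives 4080 nM, a number that the usual scatter does not separate from those of compound 1 or compound 2.

Compound 4, `Cc1ccc(-n2cc(-c3cccc(NS(=O)(=O)c4c[nH]c(=O)[nH]c4=O)c3)nn2)cc1`, has not yet been measured. It differs from compound 3 by 4-methylphenyl in place of 3-methylphenyl on an aromatic nitrogen. The place of this change is described in the same words as for the change from compound 1 to compound 2, so it is the same change, made on the core of compound 3 instead.

Going by the values given here, the only guide to what it may do is the earlier step. From compound 3 to compound 4 the expected step in this assay is a 1.4-fold lower number from compound 3 to compound 4 (0.15 log units; within the scatter), resting on a 1.4-fold lower number from compound 1 to compound 2 (0.16 log units; within the scatter), which stayed within the scatter. For compound 4 the estimated value is therefore 2900 nM, expected to fall between 1500 nM and 6000 nM.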

Compound 4, half-maximal inhibitory concentration: 3540 nM
The estimate for compound 4 lay 1.2-fold (0.09 log units) below the measured number; the range from low to high includes it.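

Made on the second core, the swap of 3-methylphenyl for 4-methylphenyl on the aromatic nitrogen gave, in this assay, a 1.2-fold lower number from compound 3 to compound 4 (0.06 log units; within the scatter). Set beside the same swap on the first core, the two steps agree: the same change on two cores in this assay, a 1.4-fold lower number (0.16 log units; within the scatter) from compound 1 to compound 2 and a 1.2-fold lower number (0.06 log units; within the scatter) from compound 3 to compound 4, 1.2-fold (0.10 log units) apart, within the scatter of two such steps This shows that on these two cores the swap behaved alike, leaving the number indistinguishable from that of the parent compound each time, but it does not show that an effect of this swap travels from core to core, since neither step is large enough to stand out from the scatter, and agreement between two steps this small is a weak test that says little about any other core.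

The compounds shown carry only a methylphenyl group at this place, so they leave open what an amine, a carboxylic acid or a longer chain in place of the methyl would do to the number. Whether the swap would stay just as small on a core other than these two also remains an open question.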